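This account rests on a few compounds, and the source may have more. Where it says the series, first, only, none or still open, it means among the compounds named here.

Measured so far in an ADME assay on MDCK cells (Canis lupus familiaris) for cytotoxicity, read by microscopy, with a stated time of 48 h; a lower number here means that less compound is tolerated, a higher number that more compound is tolerated:
compound 1 `CCCCc1csc(CN[C@@H]2C[C@H]3C[C@@H]([C@H]2C)C3(C)C)c1` gives 12500 nM
compound 2 `C[C@H]1[C@H](NCc2ccc(C(C)(C)C)s2)C[C@H]2C[C@@H]1C2(C)C` gives 780 nM
compound 3 `C[C@H]1[C@H](NCc2ccsc2)C[C@H]2C[C@@H]1C2(C)C` gives 50000 nM

Compound 3 holds the highest of the three numbers in this assay, so of these three it is the one of which the cells tolerate the most. Nearest to it stands compound 1, whose number is lower by a margin that lies beyond the usual scatter; furthest away stands compound 2, whose number is lower still, again well beyond the scatter. Both of those carry a larger group on the five-membered ring than compound 3 does.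

The next compound, compound 4 `Cc1csc(CN[C@@H]2C[C@H]3C[C@@H]([C@H]2C)C3(C)C)n1`, has not yet been measured in this assay. It differs from compound 3 in one place: 4-methyl-1,3-thiazol-2-yl in place of thiophen-3-yl on a saturated chain carbon bound to an amine nitrogen

Going by the values given here, no step between two measured compounds describes such a change, so the expectation rests on compound 3 alone. The entering group is small, and the number of compound 3 50000 nM leaves room below it. A modest downward step, or none beyond the scatter, is expected from compound 3 to compound 4 a 2.0-fold lower number from compound 3 to compound 4 (0.30 log units; within the scatter). Compound 4 is therefore estimated at 25000 nM in this assay, with a likely range from 8000 nM to 60000 nM.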

Compound 4, minimum cytotoxic concentration: > 100000 nM
Compound 4 ended at the assay's limit (the forecaster's own chance of this, stated with the estimate: 25%); at least 4.0-fold (0.60 log units) between middle value and limit.
By their numbers in this assay, from the lowest: compound 2; then compound 1; then compound 3. At a limit, above all of these: compound 4.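

In this assay compound 4 gives > 100000 nM, which is a limit of the assay and not a number. Going by these compounds alone, replacing thiophen-3-yl with 4-methyl-1,3-thiazol-2-yl on a saturated chain carbon bound to an amine nitrogen gives the first single-place step in this set, an at least 2.0-fold higher number from compound 3 to compound 4 (0.30 log units; that floor lies within the scatter), and it shows that the change, which brings one more heavy atom and a second ring hetero atom, does not carry the number downward at this position. That step is only a floor, and its true size cannot be read from one compound capped in this way: the limit of > 100000 nM in this assay, at which 1 of the 4 values shown sits.

The ring nitrogen and the methyl group enter together in this one change, so the compounds shown do not separate what each contributes; an unsubstituted 1,3-thiazol-2-yl group at the same place would be needed to tell them apart. On these data alone, it also remains open whether a longer chain, such as butyl, on the 1,3-thiazol-2-yl ring would keep compound 4's place at the limit in this assay.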